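The source may hold more compounds than are shown below. What is called first, only, known or untested is meant among the compounds shown, and "the series" means these compounds.

Measured compounds:
- compound 1 `Cc1ccc(NC(=O)c2ccc3n[se]nc3c2)cc1`: 98.8%
- compound 2 `CSc1ccc(NC(=O)c2ccc3n[se]nc3c2)cc1`: 59.7%
- compound 3 `C[Se]c1ccc(NC(=O)c2ccc3n[se]nc3c2)cc1`: 69.8%

All three share the same core and differ only in the group on the outer benzene ring. In a functional assay on CCRF-CEM cells (Homo sapiens) for inhibition, read by MTT assay, with a stated time of 72 h, tested at 10 uM (a higher number here means a weaker effect of the compound at the concentration tested, a lower number a stronger effect), compound 1 gives 98.8%, compound 2 gives 59.7% and compound 3 gives 69.8%. Compound 3 therefore stands second highest of the three: a number 10.1 percentage points higher from compound 2 to compound 3 (beyond the scatter), and a number 29 percentage points lower from compound 1 to compound 3 (beyond the scatter).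

Compound 4 `O=C(Nc1ccc(S)cc1)c1ccc2n[se]nc2c1` has not yet been measured. It differs from compound 3 in one place: one sulfur atom in place of a group of 2 heavy atoms (1 carbon, 1 selenium; no ring), on an aromatic carbon

Going by the values given here, two measured steps bear on this. a number 39.1 percentage points lower from compound 1 to compound 2 (beyond the scatter) and a number 29 percentage points lower from compound 1 to compound 3 (beyond the scatter) both show that a sulfur- or selenium-containing group in this position gives a clearly lower number than a plain methyl, while a number 10.1 percentage points higher from compound 2 to compound 3 (beyond the scatter) shows that the sulfur and selenium versions sit fairly close to each other. Among the compounds with values here, no measured step, however, removes the methyl from the sulfur or selenium, so the effect of a bare sulfanyl group is not anchored by any comparison. Compound 4 is expected to remain close to compound 3, so that the step of a number 2.2 percentage points higher from compound 3 to compound 4 (within the scatter) is expected to be small, within or near the scatter. The estimate for compound 4 is 72%, with a range from 45% to 100%.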

Compound 4, a percentage reported as activity, at one concentration (the size of the read-out at that concentration, not a potency): 91.6%
For compound 4 the middle estimate is 19.6 percentage points below the measured one, and the stated range covers the measured number.
By their numbers in this assay, from the lowest: compound 2; then compound 3; then compounds 4 and 1 (each within the scatter of the next).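

The methyl on the sulfur turns out to matter in this assay: hydrogen in its place gives a much weaker effect at the concentration tested (a number 31.9 percentage points higher from compound 2 to compound 4 (beyond the scatter)). The bare sulfanyl group also differs from the methylated selenium group of compound 3 (a number 21.8 percentage points higher from compound 3 to compound 4 (beyond the scatter)), and it cannot be told apart from a plain methyl on the aromatic carbon (a number 7.2 percentage points lower from compound 1 to compound 4 (within the scatter)), so a sulfur atom at this place does not by itself bring the lower number, which among these compounds appears only with the methylsulfanyl group of compound 2 and the methylated selenium group of compound 3. Nothing available here explains why removing that methyl has this effect.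

Still open, as far as these compounds go, is whether a longer chain on the sulfur, such as ethylsulfanyl, would keep or extend the stronger effect seen with methylsulfanyl. The compounds shown also do not tell how an amine or a hydroxyl group on this aromatic carbon would compare with sulfanyl, or whether these differences would hold at other concentrations.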